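This account rests on a few compounds, and the source may have more. Where it says the series, first, only, none or still open, it means among the compounds named here.

The measured compounds, each tested in an ADME assay on microsomes from liver (Homo sapiens) for metabolic stability, with a stated time of 30 min; a higher number here means that more of the compound is left, a lower number that less of the compound is left:

Compound 1 `CCCCc1nc(C(C)C)c(CC(=O)OCCC)c(=O)n1Cc1ccc(-c2ccccc2-c2noc(=O)[nH]2)cc1` gives 7.2%.
Compound 2 `CCCCOC(=O)Cc1c(C(C)C)nc(CCCC)n(Cc2ccc(-c3ccccc3-c3noc(=O)[nH]3)cc2)c1=O` gives 7.1%.
Compound 3 `CCCCc1nc(C(C)C)c(CC(=O)OC2CC2)c(=O)n1Cc1ccc(-c2ccccc2-c2noc(=O)[nH]2)cc1` gives 10.3%.

Compound 2 holds the lowest of the three numbers, but it is not set apart from the others: a number 0.1 percentage points lower from compound 1 to compound 2 (within the scatter) and a number 3.2 percentage points higher from compound 2 to compound 3 (within the scatter) are both steps within the scatter, and so is a number 3.1 percentage points higher from compound 1 to compound 3 (within the scatter). The three compounds share one core and differ only in the group sitting on the oxygen next to a carbonyl group; across propyl, butyl and cyclopropyl this assay has not moved beyond its scatter in any direction.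

Compound 4 `CCCCc1nc(C(C)C)c(CC(=O)OC(CC)CC)c(=O)n1Cc1ccc(-c2ccccc2-c2noc(=O)[nH]2)cc1` continues along the same line: pentan-3-yl in place of butyl on an oxygen next to a carbonyl group. Within the data shown here, the steps that bear on this change are the three above, from compound 1 to compound 2, from compound 2 to compound 3 and from compound 1 to compound 3, none of them beyond the scatter. On that basis no step beyond the scatter is expected in this assay when butyl gives way to pentan-3-yl. Compound 4 is therefore estimated to give about 8% in this assay, with a range from 3% to 16%. The estimate for compound 4 implies a number 0.9 percentage points higher from compound 2 to compound 4 (within the scatter), a step expected to remain within the scatter.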

Compound 4, percent of the compound remaining: 7.7%
The estimate for compound 4 lay 0.3 percentage points above the measured number; measured number inside the range.
By their numbers in this assay, from the lowest: compounds 2, 1, 4 and 3 (each within the scatter of the next).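

In this assay, pentan-3-yl in place of butyl on an oxygen next to a carbonyl group gives a number 0.6 percentage points higher from compound 2 to compound 4 (within the scatter), so a group of 5 heavy atoms stands level with one of 4 at this place. The other two comparisons read the same way: a number 2.6 percentage points lower from compound 3 to compound 4 (within the scatter) for the change from cyclopropyl, and a number 0.5 percentage points higher from compound 1 to compound 4 (within the scatter) for ethyl in place of hydrogen on a saturated chain carbon bound to an oxygen next to a carbonyl group and a saturated chain carbon. With pentan-3-yl added to propyl, butyl and cyclopropyl, all four groups on this oxygen lie within the scatter of one another in this assay, and the new compound widens the set of groups without producing a step beyond it.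

No measurement is at hand that would explain this flat result. The compounds shown leave open whether a group of another kind on this oxygen, such as a chain carrying an amine or a hydroxyl, or a benzyl group, or a free carboxylic acid in place of the ester, would move the number beyond the scatter.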